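Removing one methoxy group from the trimethoxy analogue

The source may report more compounds than this note shows. Statements on the series, on what has been measured and on what is new or still open speak of the compounds shown alone.

Of the compounds shown here, two of a shared core have been tested for cytotoxicity against melanoma cells. Compound 1 `COc1ccc(-c2cc(/C=C/C(=O)c3ccc(N)cc3)[nH]n2)cc1` carries a single methoxy group on its aryl ring, and compound 2 `COc1cc(-c2cc(/C=C/C(=O)c3ccc(N)cc3)[nH]n2)cc(OC)c1OC` carries three. In a functional assay on SK-MEL-5 cells (Homo sapiens) for cytotoxicity, read by sulforhodamine B assay, with a stated time of 48 h, tested at 0.01 uM (a higher number here means a weaker effect of the compound at the concentration tested, a lower number a stronger effect), compound 1 gives 97%, and in this assay compound 2 gives 95%. Compound 2 stands at the lower of the two numbers, but the gap to compound 1 lies within the usual scatter of repeated measurements, so the two compounds are indistinguishable at this concentration; neither shows an appreciable effect.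

Compound 3 `COc1ccc(-c2cc(/C=C/C(=O)c3ccc(N)cc3)[nH]n2)cc1OC` has not yet been measured in this assay. It differs from compound 2 in one place: hydrogen in place of methoxy on an aromatic carbon. Among the compounds with values here, no step between two measured compounds is known to guide the expectation. Since compound 1 gives 97% and compound 2 gives 95%, both near the top of the scale, a step from compound 2 to compound 3 of a number 1 percentage points higher from compound 2 to compound 3 (within the scatter) is expected, no larger than the scatter. Compound 3 is therefore estimated at 96%, within a range of 87% to 102%.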

Compound 3, a percentage reported as activity, at one concentration (the size of the read-out at that concentration, not a potency): 99%
Beside the measured number, compound 3's estimate is 3 percentage points below it; measured number inside the range.
By their numbers in this assay, from the lowest: compounds 2, 1 and 3 (each within the scatter of the next).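

In this assay, hydrogen in place of methoxy on an aromatic carbon gives a number 4 percentage points higher from compound 2 to compound 3 (within the scatter), and methoxy in place of hydrogen on an aromatic carbon gives a number 2 percentage points higher from compound 1 to compound 3 (within the scatter). Within the data shown here, these are the first steps that change a single place, and neither separates the two compounds it joins, so at this one concentration the methoxy group at either of these places makes no difference that can be read, and compound 1, compound 2 and compound 3 cannot be told apart. Nothing measured here bears on why these steps stay so small.

From the compounds shown here alone, it remains open whether the position matters at all, as none of the three compounds shows an appreciable effect at this concentration and a difference between them could only emerge where the compounds act more strongly. Also open, going by these compounds, is whether an amine, a carboxylic acid or a longer alkoxy chain on the same aromatic carbon would give a step beyond the scatter, where methoxy and hydrogen do not.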